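Phenoxymethyl for Phenyl, Repeated on a Second Core

The source may report more compounds than this note shows. Statements on the series, on what has been measured and on what is new or still open speak of the compounds shown alone.

Measured compounds:
compound 1 `O=C(OC1CCCCC1n1cc(CN2CCC(c3ccccc3)CC2)nn1)c1ccccc1` — 16%
compound 2 `O=C(COc1ccccc1)OC1CCCCC1n1cc(CN2CCC(c3ccccc3)CC2)nn1` — 42%
compound 3 `O=C(OC1CCCCC1n1cc(CN2CCN(c3ccccc3)CC2)nn1)c1ccccc1` — 21%

In an assay on nucleic acid for inhibition of Nucleic Acid, read by fluorescence, tested at 100 uM (on this read-out higher numbers stand for more inhibition at the one concentration tested (going by the name of the read-out) and lower numbers for less inhibition), compound 1 gives 16% and compound 2 gives 42%. The change between them, (phenoxymethyl in place of phenyl on a carbonyl carbon), produced a number 26 percentage points higher from compound 1 to compound 2 (beyond the scatter). Compound 3 gives 21% in this assay; its value and that of compound 1 lie within the scatter of each other, while compound 2 stands beyond the scatter from both. The difference between the core of compound 1 and the core of compound 3 is not broken down here.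

Compound 4 `O=C(COc1ccccc1)OC1CCCCC1n1cc(CN2CCN(c3ccccc3)CC2)nn1` has not yet been measured in this assay. It differs from compound 3 by phenoxymethyl in place of phenyl on a carbonyl carbon, the same change at the same place as from compound 1 to compound 2. If the change carries over to the second core, compound 4 is expected to show a step of a number 22 percentage points higher from compound 3 to compound 4 (beyond the scatter), of about the size of a number 26 percentage points higher from compound 1 to compound 2 (beyond the scatter). Given the value 21% of compound 3, the estimate for compound 4 is 43%, with a range from 28% to 60%, resting on one prior instance only.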

Compound 4, a percentage reported as inhibition, at one concentration (the size of the read-out at that concentration, not a potency): 37%
The estimate for compound 4 lay 6 percentage points above the measured number; the range from low to high includes it.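

In this assay, phenoxymethyl in place of phenyl on a carbonyl carbon gave a number 16 percentage points higher from compound 3 to compound 4 (beyond the scatter), so the change moved the read-out the same way on the second core, and the size of the step cannot be told apart between the two cores: the same change on two cores in this assay, a number 26 percentage points higher (beyond the scatter) from compound 1 to compound 2 and a number 16 percentage points higher (beyond the scatter) from compound 3 to compound 4, 10 percentage points apart, within the scatter of two such steps This agreement rests on two cores with a single pair each, so it supports carrying the change between these two cores and says nothing about any other core in the series. The read-out is also inhibition at one concentration rather than a potency, and the pairs do not show why the change raises it.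

The compounds shown leave open whether the step follows from the oxygen of the phenoxymethyl group or from the longer link to the phenyl ring, a question that a benzyl or phenethyl group at the same place could address. They also leave open how an amine or a carboxylic acid carried on the phenoxymethyl group would read in this assay.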